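The compounds below may be only part of what the source reports. "The series", "measured", "known", "first", "only" and "open" are said of these compounds alone.

Measured compounds in a functional assay on MCF7 cells (Homo sapiens) for inhibition, read by MTT assay, with a stated time of 72 h; a higher number here means a weaker inhibitor, a lower number a stronger inhibitor:
- compound 1 `Cc1cc(Nc2cc(-c3ccccc3)[nH]n2)n2nc(SCc3ccc(Cl)cc3)nc2n1`, 8260 nM
- compound 2 `Cc1ccc(Cn2ccc(Nc3cc(C)nc4nc(SCc5ccc(Br)cc5)nn34)n2)cc1`, 11300 nM
- compound 3 `Cc1nc2nc(SCc3ccc(Cl)cc3)nn2c(Nc2cc(-c3ccccc3)[nH]n2)c1C`, 10600 nM

Within the data shown here, compound 1 gives the lowest of the three numbers, but the other two sit within the scatter of it: compound 3 is a step of a 1.3-fold higher number from compound 1 to compound 3 (0.11 log units; within the scatter) away, and compound 2 differs from compound 1 in more than one place, so its value is simply read beside that of compound 1 with no step drawn. On these numbers the three compounds are not separated.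

Compound 4 `COc1ccc(CSc2nc3nc(C)cc(Nc4cc(-c5ccccc5)[nH]n4)n3n2)cc1` is the next compound for this assay. It differs from compound 1 by one change: methoxy in place of chloro on an aromatic carbon. The change sits on the six-membered aromatic ring of carbon only, para to a large group.

Among the measured compounds shown here, none of the measured steps touches this part of the shared core. For the measured compounds named here, the only single-place step in hand, a 1.3-fold higher number from compound 1 to compound 3 (0.11 log units; within the scatter), is a methyl in place of hydrogen elsewhere and lies within the scatter. Going by the values given here, there is no measured step that probes a swap of the group at this position, so there is no basis for expecting a shift in either direction beyond the scatter.

Compound 4 is therefore expected to land close to compound 1, with an estimated step of a 1.1-fold higher number from compound 1 to compound 4 (0.04 log units; within the scatter) and an estimated value of 9000 nM, expected to fall between 3500 nM and 23000 nM.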

Compound 4, half-maximal inhibitory concentration: 4020 nM
For compound 4 the middle estimate is 2.2-fold (0.35 log units) above the measured one, within the range that was stated.
By their numbers in this assay, from the lowest: compound 4; then compounds 1, 3 and 2 (each within the scatter of the next).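

In this assay, going from 4-chlorobenzyl to 4-methoxybenzyl on the sulfur gives a 2.1-fold lower number from compound 1 to compound 4 (0.31 log units; beyond the scatter), a modest step, but the first among the compounds shown to lie beyond the scatter. Among these compounds, the only earlier single-place step, a 1.3-fold higher number from compound 1 to compound 3 (0.11 log units; within the scatter), concerns a methyl in place of hydrogen elsewhere on the compound and did not separate its two compounds, so this aromatic carbon is the one place so far where a single change moves the number past the scatter. The series therefore responds to a swap at this position, though this rests on a single pair of compounds, and nothing measured here bears on what lies behind the lower number.

As far as these compounds go, with only chloro and methoxy compared directly at this position, it remains open whether the lower number is particular to methoxy or would also appear with a hydroxy group, a longer ethoxy chain, an amine or a carboxylic acid on the same carbon. From the compounds shown here alone, it also remains open whether methoxy in place of chloro gives a step of similar size on the methyl-bearing core of compound 3, or on other amino groups attached to the shared core.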